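The source may hold more compounds than are shown below. What is called first, only, known or untested is meant among the compounds shown, and "the series" means these compounds.

Measured in an ADME assay on CCRF-HSB-2 cells (Homo sapiens) for cytotoxicity, with a stated time of 7 days; a lower number here means that less compound is tolerated, a higher number that more compound is tolerated:
- Compound 1 `Nc1nc(NCc2ccccc2)c2ncn(/C=C3/CC3(CO)CO)c2n1`: > 20000 nM, a limit
- Compound 2 `CC(C)Nc1nc(N)nc2c1ncn2/C=C1/CC1(CO)CO`: > 20000 nM, a limit
- Compound 3 `Nc1nc(NC2CCCCC2)c2ncn(/C=C3/CC3(CO)CO)c2n1`: > 20000 nM, a limit

For the measured compounds named here, compound 3 thus has no number, only a limit, and the series so far shows only (the limit of > 20000 nM in this assay, at which 3 of the 3 values shown sit). Compound 4 `CC(C)Sc1nc(N)nc2c1ncn2/C=C1/CC1(CO)CO` has isopropylsulfanyl in place of cyclohexylamino on an aromatic carbon. Going by the values given here, the steps that bear on this are a step that the two limits leave unreadable from compound 1 to compound 3 and a step that the two limits leave unreadable from compound 2 to compound 3, so neither supplies a size to carry over. Among the compounds with values here, no measured compound carries isopropylsulfanyl. In this assay, the expected change is a number no higher from compound 3 to compound 4 (the limit leaves the size open), with its direction left open. Compound 4 is estimated at 20000 nM, with an expected range of 6000 nM to 40000 nM.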

Compound 4, half-maximal cytotoxic concentration: 94000 nM
Compound 4: middle estimate off by 4.7-fold (0.67 log units), on the low side, outside the stated range (above it).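

No step to compound 4 can be read in this assay, as compound 1, compound 2 and compound 3 each carry only a limit: the limit of > 20000 nM in this assay, at which 3 of the 4 values shown sit.

The compounds shown leave open how far isopropylsulfanyl differs in size of read-out from isopropylamino, cyclohexylamino or benzylamino.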